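A few compounds are considered here, and "the series" means these few. Any claim that something is new, unique, unknown or untested is made for them only; others in the source may bear on it.

Compound 1 `O=S(=O)(Nc1ccc(-c2nc3ccccc3o2)cc1)c1ccccc1F` is the parent of this small set. In an assay on cells for inhibition of HSP60/HSP10 (Homo sapiens), with a stated time of 60 min (on this read-out lower numbers stand for stronger inhibition and higher numbers for weaker inhibition), compound 1 gives only a limit of the assay, > 100000 nM. Compound 2 `O=S(=O)(Nc1ccc(-c2nc3cc(NS(=O)(=O)c4ccccc4F)ccc3o2)cc1)c1ccccc1F`, which carries a further ((2-fluorophenyl)sulfonyl)amino group on the shared core, gives 57000 nM in this assay, and compound 3 `O=S(=O)(Nc1ccc(-c2nc3ccccc3o2)cc1)c1ccccc1C(F)(F)F`, with trifluoromethyl in place of fluoro, gives 74000 nM. Both measured steps stay small: an at least 1.7-fold lower number from compound 1 to compound 2 (0.24 log units; that floor lies within the scatter) and an at least 1.3-fold lower number from compound 1 to compound 3 (0.13 log units; that floor lies within the scatter). Compound 4 `O=S(=O)(Nc1ccc(-c2nc3ccccc3o2)cc1)c1ccc(Cl)cc1` has not yet been measured. Its change from compound 1 is 4-chlorophenyl in place of 2-fluorophenyl on a sulfonyl sulfur. Within the data shown here, only the step from compound 1 to compound 3 alters the same sulfonyl aryl group, and it stayed at a floor within the scatter, so no step beyond the scatter is expected here. Compound 4 is therefore estimated at 80000 nM, within 30000 nM to 250000 nM, which corresponds to the expected step of an at least 1.2-fold lower number from compound 1 to compound 4 (0.09 log units; that floor lies within the scatter).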

Compound 4, half-maximal inhibitory concentration: 61000 nM
Estimate against measurement, compound 4: 1.3-fold (0.12 log units) above, and the stated range covers the measured number.
By their numbers in this assay, from the lowest: compounds 2, 4 and 3 (each within the scatter of the next). At a limit, above all of these: compound 1.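

In this assay, 4-chlorophenyl in place of 2-fluorophenyl on a sulfonyl sulfur gives an at least 1.6-fold lower number from compound 1 to compound 4 (0.21 log units; that floor lies within the scatter), so a second replacement of this aryl group also yields a number rather than a limit. Compound 3 and compound 4 sit within the scatter of each other, so chlorine in the 4-chlorophenyl group and the trifluoromethyl change cannot be told apart here. Compound 1 is itself a limit, so this step is only a floor: the limit of > 100000 nM in this assay, at which 1 of the 4 values shown sits.

Going by these compounds, how far compound 1 truly lies from compound 4 stays open. Also open, on these data alone, is whether an amine or a carboxylic acid on this aryl group would give a step beyond the scatter.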